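This account rests on a few compounds, and the source may have more. Where it says the series, first, only, none or still open, it means among the compounds named here.

Measured so far in an ADME assay on microsomes from liver (Homo sapiens) for metabolic stability, tested at 2.5 uM; on this read-out lower numbers stand for slow clearance and higher numbers for fast clearance:
compound 1 `COc1ccc(-c2c(S(=O)(=O)c3cccc(F)c3)cnc3cc(F)ccc23)cc1` — 1.89 mL/min
compound 2 `COc1ccc(-c2c(S(=O)(=O)c3ccc(OC)cc3)cnc3cc(F)ccc23)cc1` — 1.18 mL/min
compound 3 `COc1ccc(-c2c(S(=O)(=O)c3ccc(F)cc3)cnc3cc(F)ccc23)cc1` — 1.77 mL/min

Compound 1 has the highest of the three numbers, though each step to the others lies within the scatter: a 1.1-fold lower number from compound 1 to compound 3 (0.03 log units; within the scatter), and a 1.6-fold lower number from compound 1 to compound 2 (0.20 log units; within the scatter). None of the three can be set apart on these values.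

Compound 4 `O=S(=O)(c1cccc(F)c1)c1cnc2cc(F)ccc2c1-c1cccc(F)c1` has not been measured. It differs from compound 1 in one place: 3-fluorophenyl in place of 4-methoxyphenyl on an aromatic carbon. Among the measured steps, an exchange of fluoro and methoxy on an aromatic carbon has been seen once, on the aryl group of the sulfonyl sulfur rather than at this place: a 1.5-fold higher number from compound 2 to compound 3 (0.18 log units; within the scatter). The reverse exchange, a 1.6-fold lower number from compound 1 to compound 2 (0.20 log units; within the scatter), was of the same size. Both lay within the scatter. The place varied in compound 4 was not varied among the measured compounds, so carry-over from those steps is uncertain. For compound 4 a step of at most the scatter, if anything upward, is expected: a 1.2-fold higher number from compound 1 to compound 4 (0.07 log units; within the scatter). In this assay compound 4 is therefore estimated at 2.2 mL/min, with a range of 1.3 mL/min to 3.8 mL/min.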

Compound 4, intrinsic clearance in a liver preparation (reported as CLH), per the amount of preparation that the assay uses: 0.24 mL/min
Compound 4: middle estimate off by 9.2-fold (0.96 log units), on the high side, and the stated range ends above it.
By their numbers in this assay, from the lowest: compound 4; then compounds 2, 3 and 1 (each within the scatter of the next).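

Within the data shown here, the aryl group on the aromatic carbon opposite the ring nitrogen is the first place where a single change moves the read-out beyond the scatter: in this assay, 3-fluorophenyl in place of 4-methoxyphenyl gives (a 7.9-fold lower number from compound 1 to compound 4 (0.90 log units; beyond the scatter)). The aryl changes on the sulfonyl sulfur among compound 1, compound 2 and compound 3 all stayed within the scatter, so those steps gave no guide to this place. Nothing measured here accounts for the size of this step.

Still open, from the compounds shown here alone, is whether the step follows from losing the methoxy, from gaining the fluoro or from where the substituent sits on the ring, and whether it holds with the sulfonyl aryl groups of compound 2 and compound 3. Also open, going by these compounds, is how this place responds to an unsubstituted phenyl, an amine or a carboxylic acid.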